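Propyl in place of naphthalen-2-yl on the exocyclic carbon

This account rests on a few compounds, and the source may have more. Where it says the series, first, only, none or still open, it means among the compounds named here.

Among the measured compounds shown here, compound 2 `CC(=O)OC[C@H]1O[C@@H](n2cc(CN3C(=O)/C(=C\c4ccc5ccccc5c4)c4ccccc43)nn2)[C@H](OC(C)=O)[C@@H](OC(C)=O)[C@@H]1OC(C)=O` gives 80000 nM in an ADME assay on NIH3T3 cells (Homo sapiens) for cytotoxicity, read by sulforhodamine B assay, with a stated time of 48 h (on this read-out lower numbers stand for stronger inhibition and higher numbers for weaker inhibition), the highest of the two numbers so far; compound 1 `CC(=O)OC[C@H]1O[C@@H](n2cc(CN3C(=O)/C(=C\c4ccccc4)c4ccccc43)nn2)[C@H](OC(C)=O)[C@@H](OC(C)=O)[C@@H]1OC(C)=O` gives 22800 nM. Compound 3 `CCC/C=C1\C(=O)N(Cc2cn([C@@H]3O[C@H](COC(C)=O)[C@@H](OC(C)=O)[C@H](OC(C)=O)[C@H]3OC(C)=O)nn2)c2ccccc21` differs from compound 2 by propyl in place of naphthalen-2-yl on a double-bonded chain carbon bound to a double-bonded ring carbon. For the measured compounds named here, the one measured step at that position, a 3.5-fold higher number from compound 1 to compound 2 (0.55 log units; beyond the scatter), shows the larger aromatic group raising the number, so the move to a small chain is expected to lower it, though no direct precedent exists. Compound 3 is therefore estimated at 40000 nM, between 15000 nM and 100000 nM. This expectation corresponds to an estimated step of a 2.0-fold lower number from compound 2 to compound 3 (0.30 log units; within the scatter).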

Compound 3, half-maximal inhibitory concentration: > 100000 nM
Compound 3 was reported as a limit; the forecaster's own chance of this, stated with the estimate: 20%; at least 2.5-fold (0.39 log units) between middle value and limit.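

In this assay compound 3 stands at a limit of the assay, not at a number: the limit of > 100000 nM in this assay, at which 1 of the 3 values shown sits. Propyl therefore does not lower the number at this position: phenyl keeps the lowest value of the three, with an at least 4.3-fold higher number from compound 1 to compound 3 (0.64 log units; beyond the scatter), so both replacements of phenyl raise it. Against naphthalen-2-yl the reading is only an at least 1.2-fold higher number from compound 2 to compound 3 (0.09 log units; that floor lies within the scatter), which gives no order between those two compounds. Going by these compounds, whether an amine or a hydroxyl on the phenyl, or a longer chain in place of propyl, would bring the number below that of compound 1 stays open.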